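Series notes: chain length on the shared core

This account rests on a few compounds, and the source may have more. Where it says the series, first, only, none or still open, it means among the compounds named here.

Measured compounds in an in vitro assay on U2OS cells for agonist activity at neurotensin receptor type 2 (Homo sapiens), read by reporter gene assay and beta-arrestin recruitment; a lower number here means that less compound is needed, a higher number that more compound is needed for the effect:
- compound 1, `COc1cc2nc(C3CCC3)nc(N3CCN(c4ccccc4F)CC3)c2cc1OC`: compound 1 gives > 80000 nM, a limit of the assay.
- compound 2, `COc1cc2nc(C3CCC3)nc(N3CCN(c4ccccc4Cl)CC3)c2cc1OC`: compound 2 gives > 80000 nM, a limit of the assay.
- compound 3, `COc1cc2nc(C)nc(N3CCN(c4ccccc4OC)CC3)c2cc1OC`: compound 3 gives > 80000 nM, a limit of the assay.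

Compound 3 stands at the same limit as the other two; all three sit at the limit of > 80000 nM in this assay, at which 3 of the 3 values shown sit, so no ordering among them can be read. For the measured compounds named here, the single step between measured compounds that differ in one place, a step that the two limits leave unreadable from compound 1 to compound 2, is unreadable for the same reason.

Compound 4, `CCCc1nc(N2CCN(c3ccccc3OC)CC2)c2cc(OC)c(OC)cc2n1`, is not yet measured. It differs from compound 3 by ethyl in place of hydrogen on a saturated chain carbon bound to an aromatic carbon. Going by the values given here, no measured step touches this position, and the one step available gives no size, so nothing in the present numbers supports a direction for the step from compound 3 to compound 4, and the expectation is that the value of compound 4 will again be reported as a limit rather than as a number.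

Compound 4 is therefore estimated at 100000 nM in this assay, with a range from 20000 nM to 500000 nM. The step that the limit leaves unreadable from compound 3 to compound 4 is expected, on the evidence shown, to be no more readable than the one already measured.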

Compound 4, half-maximal effective concentration: > 80000 nM
Compound 4 was reported as a limit (the forecaster's own chance of this, stated with the estimate: 85%); the middle value is on the limit's open side.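

In this assay compound 4 gives > 80000 nM as a limit of the assay. The step from compound 3 to compound 4 cannot be read, and the series stays at a single limit: the limit of > 80000 nM in this assay, at which 4 of the 4 values shown sit.

The compounds shown leave open whether any change on the shared core gives a readable value in this assay at all.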